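Thiazole acetic acids: pyridyl variation at the arylated ring carbon

The compounds below may be only part of what the source reports. "The series", "measured", "known", "first", "only" and "open" are said of these compounds alone.

Measured compounds:
compound 1, `O=C(O)Cc1sc(Cc2ccccc2)nc1-c1ccc(Cl)cc1`: 50%
compound 2, `O=C(O)Cc1sc(C(c2ccc(F)cc2)c2ccc(F)cc2)nc1-c1cc(F)nc(F)c1`: 80%

In an in vitro functional assay on HEK285-7 cells for antagonist activity at prostaglandin D2 receptor 2 (Homo sapiens), read by BRET and beta-arrestin recruitment (a higher number here means a larger maximal response, a lower number a smaller maximal response), compound 2 gives 80% and stands highest of the two numbers; compound 1 gives 50%, a lower number, and the gap between the two lies beyond the usual scatter. Among the compounds with values here, only two numbers are known, and no single-point step between measured compounds exists, so the effect of any one change on maximal response is unknown.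

Compound 3, `O=C(O)Cc1sc(C(c2ccc(F)cc2)c2ccc(F)cc2)nc1-c1ccnc(O)c1`, is not yet measured. It differs from compound 2 in one place: 2-hydroxypyridin-4-yl in place of 2,6-difluoropyridin-4-yl on an aromatic carbon. The two fluorines of the pyridyl group leave and a hydroxy group enters on the same ring. Nothing measured speaks to this exchange. A moderate step in this assay is expected, more likely downward than upward, since compound 2 holds the highest number seen.

Compound 3 is estimated to reach 62%, within 38% to 86%, the expected step being a number 18 percentage points lower from compound 2 to compound 3 (beyond the scatter).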

Compound 3, largest response reached (reported as efficacy), in percent of the reference or control that the assay uses: 60%
Estimate against measurement, compound 3: 2 percentage points above, and the stated range covers the measured number.
By their numbers in this assay, from the lowest: compounds 1 and 3 (each within the scatter of the next); then compound 2.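

In this assay the series now has its first step that can be read at a single place: exchanging 2,6-difluoropyridin-4-yl for 2-hydroxypyridin-4-yl on the aromatic carbon next to the ring nitrogen gives a number 20 percentage points lower from compound 2 to compound 3 (beyond the scatter) in maximal response. The rest of the molecule is unchanged in this pair, so the substitution on the pyridyl ring at this position is enough on its own to shift the read-out, which compounds 1 and 2, differing in more than one place, could not show. No measured property bears on this step, and whether the departure of the fluorines or the arrival of the hydroxy group accounts for it stays unresolved.

Still open, going by these compounds, is how a single fluorine on the same pyridyl ring would read. Also open, on these data alone, is whether an amine or a methoxy group in place of the hydroxy group would stay near compound 3 or move towards compound 2.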